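From propylamino to cyclopentylamino on a shared core

The source may report more compounds than this note shows. Statements on the series, on what has been measured and on what is new or still open speak of the compounds shown alone.

Compound 1 `COCCOc1nc(N)nc2c1ncn2/C=C1/CC1(CO)CO` gives > 300000 nM (a limit)
Compound 2 `Nc1nc(N2CCCC2)c2ncn(/C=C3/CC3(CO)CO)c2n1` gives > 300000 nM (a limit)
Compound 3 `CCCNc1nc(N)nc2c1ncn2/C=C1/CC1(CO)CO` gives > 300000 nM (a limit)

These three compounds share one core and were tested in an ADME assay on HFF cells (Homo sapiens) for cytotoxicity, with a stated time of 8 days; a higher number here means that more compound is tolerated, a lower number that less compound is tolerated. Compound 3 has no exact number there, only a limit of the assay (> 300000 nM). The other two compounds give no exact number either, and the whole set comes down to one entry (the limit of > 300000 nM in this assay, at which 3 of the 3 values shown sit). This means the three cannot be ranked against one another.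

Compound 4 `Nc1nc(NC2CCCC2)c2ncn(/C=C3/CC3(CO)CO)c2n1` changes one group of compound 3: cyclopentyl in place of propyl on a nitrogen on an aromatic ring. Read one bond further out, this is propylamino to cyclopentylamino.

Within the data shown here, three measured steps bear on this change. The closest is a step that the two limits leave unreadable from compound 2 to compound 3, where propylamino replaces pyrrolidin-1-yl. The others are a step that the two limits leave unreadable from compound 1 to compound 2 and a step that the two limits leave unreadable from compound 1 to compound 3. None has a readable size, so they point in no direction, and no step beyond the usual scatter is expected in this assay. The estimated change is an at least 1.0-fold lower number from compound 3 to compound 4 (0.02 log units; that floor lies within the scatter). Compound 4 may well be reported only as a limit too. As a number, compound 4 is expected at 280000 nM. The estimated range for compound 4 runs from 100000 nM to 300000 nM.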

Compound 4, half-maximal cytotoxic concentration: > 300000 nM
Compound 4 was reported as a limit; the forecaster's own chance of this, stated with the estimate: 65%; at least 1.0-fold (0.02 log units) between middle value and limit.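

In this assay compound 4 gives > 300000 nM, which is a limit of the assay. No step from compound 1, compound 2 or compound 3 to compound 4 can be read, because all four stop at the same point: the limit of > 300000 nM in this assay, at which 4 of the 4 values shown sit.

The compounds shown leave open where the true cytotoxic concentration of each lies in this assay, and whether swapping these groups changes it at all.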